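Swapping 3,5-dimethoxyphenyl for 3-hydroxyphenyl in compound 3

The source may report more compounds than this note shows. Statements on the series, on what has been measured and on what is new or still open speak of the compounds shown alone.

Measured in a functional assay on HL-60 cells (Homo sapiens) for cytotoxicity, read by MTT assay, with a stated time of 72 h (on this read-out higher numbers stand for weaker inhibition and lower numbers for stronger inhibition), as follows
compound 1 `COc1cc(Nc2nc3ccccc3nc2S(=O)(=O)c2ccc(C)cc2)cc(OC)c1` gives 20 nM
compound 2 `O=S(=O)(c1ccc(Br)cc1)c1nc2ccccc2nc1Nc1ccccc1` gives 130 nM
compound 3 `COc1cc(Nc2nc3ccccc3nc2S(=O)(=O)c2ccc(Br)cc2)cc(OC)c1` gives 2540 nM

Compound 3 has the highest number of the three, so it is the weakest here. Compound 4 `O=S(=O)(c1ccc(Br)cc1)c1nc2ccccc2nc1Nc1cccc(O)c1` carries 3-hydroxyphenyl in place of 3,5-dimethoxyphenyl on a nitrogen on an aromatic ring. The best guide is the large step at that same place (a 20-fold higher number from compound 2 to compound 3 (1.29 log units; beyond the scatter)). The other large step (a 130-fold higher number from compound 1 to compound 3 (2.10 log units; beyond the scatter)) swaps methyl for bromo, which compound 4 keeps, so it guides less. For the measured compounds named here, no measured compound carries 3-hydroxyphenyl, so a clear move toward a lower number is expected, though probably not all the way (a 7.3-fold lower number from compound 3 to compound 4 (0.86 log units; beyond the scatter)). In this assay compound 4 is estimated at 350 nM within an expected range of 70 nM to 1800 nM for now.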

Compound 4, half-maximal inhibitory concentration: 200 nM
Compound 4: middle estimate off by 1.8-fold (0.24 log units), on the high side, within the range that was stated.
By their numbers in this assay, from the lowest: compound 1; then compounds 2 and 4 (each within the scatter of the next); then compound 3.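

In this assay, the penalty of 3,5-dimethoxyphenyl on this nitrogen does not carry over to 3-hydroxyphenyl (a 13-fold lower number from compound 3 to compound 4 (1.10 log units; beyond the scatter)). Hydroxy in place of hydrogen on the plain phenyl makes no clear difference (a 1.5-fold higher number from compound 2 to compound 4 (0.19 log units; within the scatter)), so with bromo on the sulfonyl ring, this position accepts one hydroxy group but not the two methoxy groups of compound 3. No measurement shown here explains this difference.

As far as these compounds go, whether an amine or a carboxylic acid in place of that hydroxy would give a similar number remains open. So does how 3-hydroxyphenyl behaves alongside the methyl of compound 1 instead of bromo.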